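The source may hold more compounds than are shown below. What is called first, only, known or untested is meant among the compounds shown, and "the series" means these compounds.

Two members of the series have been measured. Compound 1 `COc1cccc(NC2=CC(=O)c3c(nc4n3[C@H]3OC[C@@H](O)[C@H]3OC4)C2=O)c1` gives 3830 nM in a functional assay on MCF7 cells (Homo sapiens) for inhibition, read by sulforhodamine B assay; a higher number here means a weaker inhibitor, a lower number a stronger inhibitor; compound 2 `Cc1ccc(NC2=CC(=O)c3nc4n(c3C2=O)[C@H]2OC[C@@H](O)[C@H]2OC4)cc1C` gives 2080 nM in this assay, and the two values sit within the scatter of each other, so neither can be set apart from the other. Compound 3 `CCOc1ccc(NC2=CC(=O)c3c(nc4n3[C@H]3OC[C@@H](O)[C@H]3OC4)C2=O)cc1` is not yet measured. Relative to compound 1 it carries 4-ethoxyphenyl in place of 3-methoxyphenyl on an amine nitrogen. For the measured compounds named here, no measured pair shows this change, so the step from compound 1 to compound 3 is expected to be small, a 1.3-fold lower number from compound 1 to compound 3 (0.11 log units; within the scatter), with no direction beyond the scatter. Compound 3 is estimated at 3000 nM, expected range 1200 nM to 8000 nM.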

Compound 3, half-maximal inhibitory concentration: > 4000 nM
Compound 3 gave a limit, no number; the forecaster's own chance of this, stated with the estimate: 5%; at least 1.3-fold (0.12 log units) between middle value and limit.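

Compound 3 stands at a limit, not a number: the limit of > 4000 nM in this assay, at which 1 of the 3 values shown sits. Placing 4-ethoxyphenyl instead of 3-methoxyphenyl on the amine nitrogen gives an at least 1.0-fold higher number from compound 1 to compound 3 (0.01 log units; that floor lies within the scatter), so this first measured step at this position shows no gain in inhibition, and its true size stays unknown.

Both the place of the ether on the phenyl ring and the length of its chain change in this one step, so the step cannot be assigned to either. 4-Methoxyphenyl on the same amine nitrogen would separate the two, and a carboxylic acid on that phenyl ring remains an open test.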